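Acrylamide in place of chloropropanamide on the iodoaniline

The compounds below may be only part of what the source reports. "The series", "measured", "known", "first", "only" and "open" are said of these compounds alone.

Compound 1 `O=C(CCCl)Nc1ccc(I)cc1` gives 26000 nM in a functional assay on MCF7 cells (Homo sapiens) for antiproliferative activity, with a stated time of 48 h; on this read-out higher numbers stand for weaker inhibition and lower numbers for stronger inhibition. Compound 2 `CC(C)(C)c1ccc(NC(=O)CCCl)cc1` gives 49000 nM in this assay, and the step of a 1.9-fold higher number from compound 1 to compound 2 (0.28 log units; within the scatter) leaves the two standing within the scatter of each other. Compound 3 `CCCCC(O)c1cccc(NC(=O)CCCl)c1` reaches only the limit of this assay, > 100000 nM; the value the limit of > 100000 nM in this assay, at which 1 of the 3 values shown sits, is a limit and not a number. Among the numbers shown, compound 1 and compound 2 therefore form one pair with no difference that can be read.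

Compound 4 `C=CC(=O)Nc1ccc(I)cc1` differs from compound 1 by vinyl in place of 2-chloroethyl on a carbonyl carbon. Among the measured compounds shown here, the only measured step, from compound 1 to compound 2, changes a substituent on the aromatic ring, not the carbonyl carbon, and was within the scatter; no measured step touches the amide chain itself. The series thus gives no basis for a step in either direction beyond the scatter. Compound 4 is expected to stay close to compound 1, with an estimated step of a 1.4-fold lower number from compound 1 to compound 4 (0.16 log units; within the scatter). The estimate for compound 4 is 18000 nM, with a range from 3000 nM to 90000 nM.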

Compound 4, half-maximal inhibitory concentration: 17000 nM
Compound 4: middle estimate off by 1.1-fold (0.02 log units), on the high side, within the range that was stated.
By their numbers in this assay, from the lowest: compounds 4, 1 and 2 (each within the scatter of the next, the first and the last beyond it). At a limit, above all of these: compound 3.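

Among the compounds shown here, this is the first measured change on the carbonyl carbon: in this assay, vinyl in place of 2-chloroethyl gives a 1.5-fold lower number from compound 1 to compound 4 (0.18 log units; within the scatter), and the two groups cannot be told apart on this read-out with the core of compound 1. The earlier step changed only a substituent on an aromatic carbon, whereas this pair shows that the chlorine on the amide chain can go without a readable change, at least on this core. Nothing at hand bears on the cause of this result.

Open, on these data alone, is whether a plain ethyl group, a longer chain or a chain carrying an amine on the carbonyl carbon would stay within the same range. Also open, as far as these compounds go, is whether vinyl in place of 2-chloroethyl would give the same result on the core of compound 2.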